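From a 4-fluorophenyl to a 4-methoxyphenyl on a shared core

The source may report more compounds than this note shows. Statements on the series, on what has been measured and on what is new or still open speak of the compounds shown alone.

Of the compounds shown here, three have been measured in a functional assay on A549 cells (Homo sapiens) for cytotoxicity, read by MTT assay, with a stated time of 48 h; on this read-out higher numbers stand for weaker inhibition and lower numbers for stronger inhibition. Within the data shown here, compound 1 `COc1ccc(-c2cc(C(=O)Nc3nc4ccc(F)cc4s3)nc3cc(-c4ccccc4)nn23)cc1` gives 11700 nM, and compound 2 `COc1ccc(-c2cc(C(=O)Nc3nc4ccccc4s3)nc3cc(-c4ccccc4)nn23)cc1` gives 1540 nM; the single change between them, hydrogen in place of fluoro on an aromatic carbon, gave a 7.6-fold lower number from compound 1 to compound 2 (0.88 log units; beyond the scatter). Compound 3 `Cc1cc2nc(NC(=O)c3cc(-c4ccc(F)cc4)n4nc(-c5ccccc5)cc4n3)sc2cc1C` gives 12600 nM, the highest of the three numbers shown, though within the scatter of compound 1 and beyond it only against compound 2. Compound 4 `COc1ccc(-c2cc(C(=O)Nc3nc4cc(C)c(C)cc4s3)nc3cc(-c4ccccc4)nn23)cc1` has not been measured; it differs from compound 3 by methoxy in place of fluoro on an aromatic carbon. Among the measured compounds shown here, no measured step covers this exchange: the one known step sits on another part of the shared core and offers no guide here. The step of a 1.6-fold lower number from compound 3 to compound 4 (0.20 log units; within the scatter) is therefore expected to remain within the scatter. Compound 4 is estimated at 8000 nM in this assay, between 2500 nM and 25000 nM.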

Compound 4, half-maximal inhibitory concentration: 13200 nM
Compound 4: the middle estimate sits 1.7-fold (0.22 log units) below what was measured, and the stated range covers the measured number.
By their numbers in this assay, from the lowest: compound 2; then compounds 1, 3 and 4 (each within the scatter of the next).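

In this assay the exchange of 4-fluorophenyl for 4-methoxyphenyl stays within the scatter (a 1.0-fold higher number from compound 3 to compound 4 (0.02 log units; within the scatter)), so this position shows no response to this change on the dimethylated compounds. The 5,6-dimethyl-1,3-benzothiazol-2-yl group matters only against the unsubstituted 1,3-benzothiazol-2-yl (an 8.6-fold higher number from compound 2 to compound 4 (0.93 log units; beyond the scatter)), not against 6-fluoro-1,3-benzothiazol-2-yl (a 1.1-fold higher number from compound 1 to compound 4 (0.05 log units; within the scatter)), leaving compound 2 alone among the methoxy compounds. No evidence here accounts for these results. From the compounds shown here alone, whether the same exchange would read alike on the unsubstituted 1,3-benzothiazol-2-yl compound stays open. So does the effect of an amine or a carboxylic acid at this position.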